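A few compounds are considered here, and "the series" means these few. Any claim that something is new, unique, unknown or untested is made for them only; others in the source may bear on it.

Series notes, aryl ether acid chain with an acyl phenol head.

Three members carry numbers. Compound 1, `Cc1c(OCCCCOc2ccccc2C(=O)O)ccc(C(=O)CC2CCCC2)c1C`, gives in an assay on HEK293 cells for positive allosteric modulation of metabotropic glutamate receptor 2 (Rattus norvegicus), read by thallium flux, with a stated time of 2.5 min (on this read-out higher numbers stand for an effect only at larger amounts of compound and lower numbers for an effect already at smaller amounts), a value of 2580 nM. Compound 2, `Cc1c(OCCCCOc2ccc(C(=O)O)cc2Cl)ccc(C(=O)CC2CCCC2)c1O`, gives in this assay a value of 237 nM. Compound 3, `CCC(=O)c1ccc(OCCCCOc2cc(C(=O)O)ccc2OC)c(C)c1O`, gives in this assay a value of 162 nM. Among these three numbers compound 3 carries the lowest, but its gap to compound 2 lies within the scatter, so the two cannot be set in order; the gap to compound 1 lies beyond the scatter, and compound 1 is the one member whose number clearly stands apart.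

The next member, compound 4, `COc1ccc(C(=O)O)cc1OCCCCOc1ccc(C(=O)C(C)C)c(O)c1C`, is not yet measured. Relative to compound 3 the change is confined to the acyl group: methyl in place of hydrogen on a saturated chain carbon bound to a carbonyl carbon and a saturated chain carbon, read one bond further out as propanoyl to isopropylcarbonyl. The rest of the molecule is unchanged. Among the compounds with values here, no pair in the measured set isolates this change, so the comparison rests on the branching alone.

The step is expected to be a 1.2-fold higher number from compound 3 to compound 4 (0.09 log units; within the scatter), in either direction no larger than the scatter. Compound 4 is expected to give about 200 nM, with a range from 80 nM to 500 nM.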

Compound 4, half-maximal effective concentration: 116 nM
For compound 4 the middle estimate is 1.7-fold (0.24 log units) above the measured one, within the range that was stated.
By their numbers in this assay, from the lowest: compounds 4, 3 and 2 (each within the scatter of the next, the first and the last beyond it); then compound 1.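

Within the data shown here, compound 3 and compound 4 form the only pair that differs in one place, so the acyl group can now be read on its own. In this assay, methyl in place of hydrogen on a saturated chain carbon bound to a carbonyl carbon and a saturated chain carbon, which turns propanoyl into isopropylcarbonyl, gives a 1.4-fold lower number from compound 3 to compound 4 (0.15 log units; within the scatter), and the two compounds cannot be set in order. Branching at this carbon is therefore accepted without a change that can be told from the scatter, and the earlier compounds, which differ from each other in several places, could not show this. Nothing at hand accounts for this result.

On these data alone, the reading rests on a single pair with the same methoxy-substituted acid ring, so it remains open whether the same holds with the other acid rings. Also open, as far as these compounds go, is how far this carbon accepts more than a methyl, for instance a second methyl giving a tert-butyl carbonyl, or an amine or a hydroxyl at the same place.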